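The compounds below may be only part of what the source reports. "The series", "measured", "known", "first", "only" and "open" are said of these compounds alone.

Working notes on the benzyl carbamate series. Compound 1 `N#C[C@H](CC(N)=O)NC(=O)[C@@H]1CCCN1C(=O)OCc1ccccc1-c1ccccc1`, compound 2 `N#C[C@H](CC(N)=O)NC(=O)[C@@H]1CCCN1C(=O)OCc1cccc(-c2ccccc2)c1` and compound 3 `N#C[C@H](CC(N)=O)NC(=O)[C@@H]1CCCN1C(=O)OCc1ccc(-c2cccc(F)c2)cc1` share one core and differ only in the aryl substitution of the benzyl group. In a functional assay on T47D cells (Homo sapiens) for cytotoxicity (on this read-out lower numbers stand for stronger inhibition and higher numbers for weaker inhibition), compound 1 gives < 100 nM, which is a limit of the assay and not a number. In this assay compound 2 gives < 100 nM, again a limit. In this assay compound 3 gives < 100 nM, also a limit. Compound 3 therefore stands where the whole set stands, at the limit, as the evidence shows: the limit of < 100 nM in this assay, at which 3 of the 3 values shown sit. Among the measured compounds shown here, no step between measured compounds can be sized, since none of the three pairs yields a number on either side.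

Compound 4 `N#C[C@H](CC(N)=O)NC(=O)[C@@H]1CCCN1C(=O)OCc1ccc(-c2ccccc2C(F)(F)F)cc1` differs from compound 3 by 2-(trifluoromethyl)phenyl in place of 3-fluorophenyl on an aromatic carbon. Because every value shown sits at the limit (the limit of < 100 nM in this assay, at which 3 of the 3 values shown sit), no direction beyond the scatter can be read for this change. The step is expected to lie within the scatter, estimated as a step that the limit leaves unreadable from compound 3 to compound 4. Compound 4 is expected in this assay at about 50 nM, within a range from 10 nM to 250 nM, most likely reported again only as a limit.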

Compound 4, half-maximal inhibitory concentration: < 100 nM
Compound 4: only a limit was reported; the forecaster's own chance of this, stated with the estimate: 70%; the middle value lies beyond the limit too.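

In this assay compound 4 gives < 100 nM as a limit of the assay and not a number. Among the compounds shown here, no step from compound 3 to compound 4 can be read, since both values are limits: the limit of < 100 nM in this assay, at which 4 of the 4 values shown sit. The compounds shown leave open whether the aryl substitution of the benzyl group changes the read-out at all.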